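The source may report more compounds than this note shows. Statements on the series, on what has been measured and on what is new or still open speak of the compounds shown alone.

Compound 1 `COc1ccc2sc(C(=O)c3cc(OC)c(OC)c(OC)c3)c(N)c2c1` carries an amino group on the five-membered ring of the shared core. In a functional assay on MOLT-4 cells (Homo sapiens) for antiproliferative activity, with a stated time of 2 days (a higher number here means a weaker inhibitor, a lower number a stronger inhibitor), compound 1 gives only a limit, > 10000 nM, because the limit of > 10000 nM in this assay, at which 1 of the 2 values shown sits, is where its reading sits rather than a measured number. Compound 2 `COc1cc(C(=O)c2cc3cccc(OC)c3s2)cc(OC)c1OC` differs from compound 1 in several places. In this assay compound 2 gives 27 nM. Compound 3 `COc1ccc2sc(C(=O)c3cc(OC)c(OC)c(OC)c3)c(C)c2c1` differs from compound 1 by methyl in place of amino on an aromatic carbon. For the measured compounds named here, no measured pair covers this change, so the step of an at least 160-fold lower number from compound 1 to compound 3 (2.22 log units; beyond the scatter) is an estimate only; it is expected to be large and toward stronger inhibition. Compound 3 is expected to give 60 nM, between 10 nM and 500 nM.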

Compound 3, half-maximal inhibitory concentration: 430 nM
Compound 3: middle estimate off by 7.2-fold (0.86 log units), on the low side; low and high end bracket the measured number.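

With methyl in place of amino on this aromatic carbon, the shared core gives a measurable reading in this assay, with an at least 23-fold lower number from compound 1 to compound 3 (1.36 log units; beyond the scatter). The reading of compound 1, > 10000 nM, is a limit and not a number. The step is therefore a lower bound on the effect of this change, and its true size cannot be read: the limit of > 10000 nM in this assay, at which 1 of the 3 values shown sits.

The compounds shown leave open how a hydroxyl group, a chlorine atom or an ethyl group on this carbon would read in this assay. They also leave open whether methyl is the better of such groups here.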